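A Methyl-to-Bromo Swap Carried Across Two Related Cores

The source may hold more compounds than are shown below. What is called first, only, known or untested is meant among the compounds shown, and "the series" means these compounds.

Compound 1 `COC(=O)[C@@]1(C)CCC=C2[C@@H]1CC[C@@H](C)[C@]2(C)Cc1c(C)[nH]c2ccc(C)cc12` and compound 2 `COC(=O)[C@@]1(C)CCC=C2[C@@H]1CC[C@@H](C)[C@]2(C)Cc1c(C)[nH]c2ccc(Br)cc12` share one core, while compound 3 `COC(=O)[C@@]1(C)CC[C@@H]2C3=C1CC[C@@H](C)[C@]3(C)C[C@@H]1c3cc(C)ccc3N[C@H]21` and compound 4 `COC(=O)[C@@]1(C)CC[C@@H]2C3=C1CC[C@@H](C)[C@]3(C)C[C@@H]1c3cc(Br)ccc3N[C@H]21` share another; the difference between the two cores is not broken down here. In a functional assay on T47D cells (Homo sapiens) for inhibition, read by sulforhodamine B assay, with a stated time of 48 h (a higher number here means a weaker inhibitor of growth, a lower number a stronger inhibitor of growth), compound 1 gives 31000 nM. In this assay compound 2 gives 16000 nM. The step between them, a 1.9-fold lower number from compound 1 to compound 2 (0.29 log units; within the scatter), comes from bromo in place of methyl on an aromatic carbon. In this assay compound 3 gives 23000 nM, a number that sits within the scatter of both compound 1 and compound 2, so no order among the three can be read from it.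

Compound 4 has not yet been measured. It differs from compound 3 by bromo in place of methyl on an aromatic carbon. This is the same kind of change as that from compound 1 to compound 2, though not the same: in compound 2 the bromo sits on an aromatic carbon that is part of a fused or bridged system of two rings, whereas in compound 4 it is part of a fused or bridged system of five rings. Because a 1.9-fold lower number from compound 1 to compound 2 (0.29 log units; within the scatter) stayed within the scatter, compound 4 is expected to move from compound 3 by a 1.6-fold lower number from compound 3 to compound 4 (0.22 log units; within the scatter), a step also expected to stay within the scatter. The estimate for compound 4 in this assay is therefore 14000 nM, with a range from 6000 nM to 35000 nM. Among the compounds with values here, this expectation rests only on the single earlier step and on the measured value of compound 3, 23000 nM.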

Compound 4, concentration for 50% growth inhibition: 31000 nM
Beside the measured number, compound 4's estimate is 2.2-fold (0.35 log units) below it, and the stated range covers the measured number.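

Within the data shown here, on the core of compound 3, bromo in place of methyl on an aromatic carbon gives, in this assay, a 1.3-fold higher number from compound 3 to compound 4 (0.13 log units; within the scatter), so this swap produces no step that can be told from the scatter on this core, just as it produced none on the core of compound 1. Set side by side, the two steps cannot be told apart, even though their printed directions are opposite: the same change on two cores in this assay, a 1.9-fold lower number (0.29 log units; within the scatter) from compound 1 to compound 2 and a 1.3-fold higher number (0.13 log units; within the scatter) from compound 3 to compound 4, 2.6-fold (0.42 log units) apart, within the scatter of two such steps

This shows that, across these two pairs, the change carries from one core to the other without a step beyond the scatter, but it does not show that the swap acts identically on both cores, that it has no effect at all, or that the opposite directions mean anything, since each core offers a single pair of compounds.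

The compounds shown carry only methyl or bromo at this aromatic carbon, so it remains open whether another group there, such as an amine, a methoxy or a nitrile, would give a step beyond the scatter on either core. All four compounds also keep the same methyl ester, which leaves open how a carboxylic acid or an amide at that place would read in this assay.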